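The compounds below may be only part of what the source reports. "The series", "measured", "known", "first", "only" and "open" are said of these compounds alone.

Working notes on the series, read in a functional assay on CWR22R cells (Homo sapiens) for antiproliferative activity, read by CCK-8 assay, with a stated time of 6 days (on this read-out higher numbers stand for weaker inhibition and lower numbers for stronger inhibition), as the only measure so far. Compound 1 `N#Cc1ccc(N2CCc3cc(-c4cncnc4)ccc32)cc1C(F)(F)F` has the entry "not determined" (no result reported) and adds no number. Compound 2 `N#Cc1ccc(N2CCCc3c(-c4cccnc4)cccc32)cc1C(F)(F)F` gives 12300 nM on its own core. Compound 3 `CCN(c1ccc(C#N)c(Cl)c1)c1cc(-c2cccs2)ccc1C` gives 22000 nM on a different core. These two numbers are all that exist, and they lie within the scatter of each other, so compound 3 stands level with compound 2 on the data shown.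

Compound 4 `CCN(c1ccc(C#N)c(Cl)c1)c1cc(-c2ccoc2)ccc1C` keeps the core of compound 3 and carries furan-3-yl in place of thiophen-2-yl on an aromatic carbon of the six-membered aromatic ring of carbon only. Among the compounds with values here, no measured pair shows what such an exchange does in this assay and no trend can be drawn from it. Within the data shown here, both groups are five-membered aromatic rings with 1 hetero atom, and the expectation rests on compound 3 at 22000 nM as the one measured compound with this core. No step beyond the scatter is expected, and no direction is called. The estimate amounts to a 1.2-fold lower number from compound 3 to compound 4 (0.09 log units; within the scatter) as an expected change. For compound 4 the estimated value is 18000 nM with an expected range from 6000 nM to 45000 nM in this assay when measured.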

Compound 4, half-maximal inhibitory concentration: > 30000 nM
Compound 4 ended at the assay's limit (the forecaster's own chance of this, stated with the estimate: 15%); middle value at least 1.6-fold (0.22 log units) from the limit.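

Within the data shown here, compounds 3 and 4 are the only pair that differ in one place, which gives this position its one readable exchange in this assay: furan-3-yl in place of thiophen-2-yl on an aromatic carbon, para to a methyl group. Compound 4 gives a limit of the assay and not a number: the limit of > 30000 nM in this assay, at which 1 of the 4 values shown sits.

The exchange amounts to an at least 1.3-fold higher number from compound 3 to compound 4 (0.13 log units; that floor lies within the scatter), so only a floor is known and the full size of the step cannot be read; no lower number appears with furan-3-yl, even though the counts of heavy atoms and hydrogen-bond acceptors match those of thiophen-2-yl.

The pair leaves open whether the change follows from the hetero atom or from the point of attachment, and furan-2-yl or thiophen-3-yl on the same core would separate the two. Also open, going by these compounds, is how this position responds to a group of another kind, such as a carboxylic acid, an amine or a longer alkyl chain, since the shared core so far carries only these two five-membered aromatic rings.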